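The compounds below may be only part of what the source reports. "The series", "measured", "known", "first", "only" and "open" are said of these compounds alone.

Values in a functional assay on KYSE-70 cells for antiproliferative activity against KYSE-70 cell line (Homo sapiens), read by MTT assay, with a stated time of 72 h; a lower number here means a stronger inhibitor, a higher number a weaker inhibitor:
- Compound 1 `O=C(Nc1cccc(F)c1)c1cc(=O)[nH]c2cc(Br)ccc12`: 8900 nM
- Compound 2 `O=C(Nc1cccc(F)c1)c1cc(=O)[nH]c2cc(F)ccc12`: > 20000 nM, a limit
- Compound 3 `O=C(Nc1cccc(F)c1)c1cc(=O)[nH]c2cc(C3CC3)ccc12`: > 20000 nM, a limit

Compound 3 has only a limit and no number of its own. The series stands at the limit of > 20000 nM in this assay, at which 2 of the 3 values shown sit, so compound 1 alone gives a number.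

Compound 4 `O=C(Nc1cccc(F)c1)c1cc(=O)[nH]c2cc(-c3ccc(F)c(CO)c3)ccc12` keeps the shared core of compound 3 and places 4-fluoro-3-(hydroxymethyl)phenyl in place of cyclopropyl on an aromatic carbon. The measured steps all fall on this same carbon. Two of them lie beyond the scatter: an at least 2.2-fold higher number from compound 1 to compound 2 (0.35 log units; beyond the scatter) and an at least 2.2-fold higher number from compound 1 to compound 3 (0.35 log units; beyond the scatter). The third cannot be sized: a step that the two limits leave unreadable from compound 2 to compound 3. None of these steps brings in a group like the one entering here, so they show only that this carbon can affect the read-out, not how this group will behave.

The expectation therefore rests on compound 1, whose 8900 nM shows that a change at this carbon can yield a number in this assay. A modest move towards stronger inhibition is expected, and a result at the limit remains quite possible. The estimated change is an at least 2.2-fold lower number from compound 3 to compound 4 (0.34 log units; beyond the scatter). For compound 4 the expected value is 9000 nM, with an estimated range from 2500 nM to 30000 nM.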

Compound 4, half-maximal inhibitory concentration: > 20000 nM
Compound 4 was reported as a limit (the forecaster's own chance of this, stated with the estimate: 35%); at least 2.2-fold (0.34 log units) between middle value and limit.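

In this assay, 4-fluoro-3-(hydroxymethyl)phenyl is the first aromatic ring shown at this carbon, and it does not bring a number back: bromo remains the only group here with a measured value, and the new group gives an at least 2.2-fold higher number from compound 1 to compound 4 (0.35 log units; beyond the scatter). Fluoro, cyclopropyl and this far larger group, which carries a hydrogen-bond donor and a hydrogen-bond acceptor, therefore all end at the same limit, so neither a larger group nor these added features restores what bromo gives among the compounds shown; the steps among compound 2, compound 3 and compound 4 cannot be read, as all three values are limits. Compound 4 thus adds a further limit rather than a number, and the series now stands at: the limit of > 20000 nM in this assay, at which 3 of the 4 values shown sit.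

The compounds shown leave open whether any other group at this carbon, such as chloro, iodo or a plain phenyl, would match or better bromo. They also leave open whether a phenyl ring carrying an amine or a carboxylic acid in place of the hydroxymethyl would give a number at all, and how compound 2, compound 3 and compound 4 rank among themselves.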